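Removing an acetyl from the core of compound 3

The source may report more compounds than this note shows. Statements on the series, on what has been measured and on what is new or still open speak of the compounds shown alone.

Measured compounds:
compound 1 `COc1ccc(C(=O)O[C@H]2CC(C)=C[C@H](O)[C@@]3(C)[C@@H](OC(C)=O)C[C@@](O)(C(C)C)[C@H]23)cc1` — 5900 nM
compound 2 `CC1=CC[C@]2(C)[C@@H]([C@@H](OC(=O)c3ccc(O)cc3)C1)[C@](O)(C(C)C)C[C@@H]2O` — 40300 nM
compound 3 `COc1ccc(C(=O)O[C@H]2CC(C)=C[C@@H](OC(C)=O)[C@@]3(C)[C@@H](OC(C)=O)C[C@@](O)(C(C)C)[C@H]23)cc1` — 62200 nM

In a functional assay on Jurkat cells (Homo sapiens) for cytotoxicity, read by MTT assay, with a stated time of 72 h (on this read-out higher numbers stand for weaker inhibition and lower numbers for stronger inhibition), compound 3 gives 62200 nM, the highest of the three numbers. The gap to compound 2, which gives 40300 nM, lies within the scatter, so the two cannot be ordered. The gap to compound 1, which gives 5900 nM, lies beyond the scatter, and compound 1 clearly stands at the lower end.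

Compound 4 `COc1ccc(C(=O)O[C@H]2CC(C)=C[C@@H](O)[C@@]3(C)[C@@H](OC(C)=O)C[C@@](O)(C(C)C)[C@H]23)cc1` is not yet measured. It differs from compound 3 in one place: hydrogen in place of acetyl on an oxygen on a saturated carbon. Within the data shown here, no step between measured compounds isolates this change, so the expectation rests on the spread of the three values. Compound 4 is expected to move toward the lower numbers, with the step of a 2.5-fold lower number from compound 3 to compound 4 (0.40 log units; beyond the scatter) estimated to reach about the edge of the scatter, given that compound 1 gives 5900 nM. Compound 4 is therefore estimated at 25000 nM, within a range from 7000 nM to 70000 nM.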

Compound 4, half-maximal inhibitory concentration: 33600 nM
Compound 4: the middle estimate sits 1.3-fold (0.13 log units) below what was measured; the measured number falls inside the stated range.
By their numbers in this assay, from the lowest: compound 1; then compounds 4, 2 and 3 (each within the scatter of the next).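

Hydrogen in place of acetyl on this oxygen on a saturated carbon does not register clearly in this assay: the acetoxy to hydroxy change gives a 1.9-fold lower number from compound 3 to compound 4 (0.27 log units; within the scatter). The drawn configuration counts for more, with a 5.7-fold higher number from compound 1 to compound 4 (0.76 log units; beyond the scatter). That step can be assigned to a single stereocentre at a saturated ring carbon, drawn S in compound 1 and R in compound 4, because nothing else separates the pair: the fact that compounds 1 and 4 differ only in the configuration as drawn

The compounds shown leave open whether an acetoxy group would also be sensitive to the configuration at that stereocentre, since only the hydroxy compounds are compared in both forms. They also leave open how an amine or a butanoyloxy group would read in place of the hydroxy, in either configuration.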